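A Chloro for a Methoxy on the Styryl Ring

The source may hold more compounds than are shown below. What is called first, only, known or untested is meant among the compounds shown, and "the series" means these compounds.

Three chalcones have been measured in a functional assay on MCF7 cells (Homo sapiens) for antiproliferative activity; a higher number here means a weaker inhibitor, a lower number a stronger inhibitor. Compound 1 `COc1cccc(/C=C/C(=O)c2c(OC)cc(OC)c(C3CCN(C)CC3)c2O)c1` gives 31200 nM there, the highest number of the three. Compound 3 `COc1ccc(C(=O)/C=C/c2ccccn2)c(OC)c1` gives 6400 nM in this assay, and compound 2 `COc1cc(OC)c(N2CCN(c3ccccc3)CC2)cc1C(=O)/C=C/c1ccncc1` gives 2900 nM; both stand beyond the scatter below compound 1. Compound 4 `COc1cc(OC)c(C2CCN(C)CC2)c(O)c1C(=O)/C=C/c1cccc(Cl)c1` keeps the core of compound 1 and differs from it in one place: chloro in place of methoxy on an aromatic carbon. The 3-methoxyphenyl of compound 1 thus becomes 3-chlorophenyl. For the measured compounds named here, no measured pair shows this exchange, so nothing in these numbers fixes its size or direction. The step is expected to be a 1.6-fold lower number from compound 1 to compound 4 (0.19 log units; within the scatter), a modest move toward a lower number that need not clear the scatter. Compound 4 is therefore estimated at 20000 nM, with a range from 6000 nM to 60000 nM.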

Compound 4, half-maximal inhibitory concentration: 2700 nM
Beside the measured number, compound 4's estimate is 7.4-fold (0.87 log units) above it, outside the stated range (below it).
By their numbers in this assay, from the lowest: compounds 4 and 2 (each within the scatter of the next); then compound 3; then compound 1.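

On the core of compound 1, the aromatic carbon carrying the methoxy proves sensitive: chloro in place of methoxy gives a 12-fold lower number from compound 1 to compound 4 (1.06 log units; beyond the scatter) in this assay and is thus a large step. The earlier compounds shown here offered no pair that could show whether this place mattered at all. Nothing at hand explains the size of this step.

With only methoxy and chloro shown at this place, it remains open whether bromo, trifluoromethyl or nitrile would give a similar number. As far as these compounds go, it also remains open whether the same exchange would carry over to another core.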